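Dropping the methyl from the urea aryl ring of compound 1

The source may hold more compounds than are shown below. What is called first, only, known or untested is meant among the compounds shown, and "the series" means these compounds.

Measured so far:
compound 1 `CNc1cc(Oc2ccc(NC(=O)Nc3cccc(C)c3)cc2)ncn1`: 1260 nM
compound 2 `Nc1cc(Oc2ccc(NC(=O)Nc3cccc(C(F)(F)F)c3)cc2)ncn1`: 25 nM
compound 3 `CNc1cc(Oc2ccc(NC(=O)Nc3cccc(C(F)(F)F)c3)cc2Cl)ncn1`: 50 nM

These three compounds share one core and were tested in an assay on isolated protein for inhibition of serine/threonine-protein kinase TNNI3K (Homo sapiens); on this read-out lower numbers stand for stronger inhibition and higher numbers for weaker inhibition. Compound 1 stands at the top of the three numbers, the weakest inhibitor here; compound 3 comes nearest to it and compound 2 is furthest away, and both gaps lie beyond the scatter. Compound 4 `CNc1cc(Oc2ccc(NC(=O)Nc3ccccc3)cc2)ncn1` is not yet measured. It differs from compound 1 in one place: hydrogen in place of methyl on an aromatic carbon, meta to a large group. For the measured compounds named here, no single-change step between measured compounds shows what this does. With no comparison to lean on, the expected outcome for compound 4 is a small shift toward a higher number in this assay, possibly within the scatter, and compound 4 is estimated at 2500 nM (range 800 nM to 8000 nM), a step of a 2.0-fold higher number from compound 1 to compound 4 (0.30 log units; within the scatter).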

Compound 4, half-maximal inhibitory concentration: 6300 nM
Compound 4: the middle estimate sits 2.5-fold (0.40 log units) below what was measured; the range from low to high includes it.
By their numbers in this assay, from the lowest: compounds 2 and 3 (each within the scatter of the next); then compound 1; then compound 4.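

In this assay, going from 3-methylphenyl to phenyl gives a 5.0-fold higher number from compound 1 to compound 4 (0.70 log units; beyond the scatter). This single-change step shows that the methyl, just one carbon at this place on the ring, makes a real difference: bare hydrogen gives weaker inhibition. No measurement shown explains this loss.

As far as these compounds go, whether ethyl, methoxy or chlorine at this place would do better or worse than methyl remains open. The separate contribution of the trifluoromethyl in compound 2 and compound 3 is also open, as no pair shown isolates it.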